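Swapping the aryl group on the thiazole-type core of compound 3

This account rests on a few compounds, and the source may have more. Where it says the series, first, only, none or still open, it means among the compounds named here.

Of the compounds shown here, three sharing one core have been tested in an in vitro functional assay on HEK285-7 cells for antagonist activity at prostaglandin D2 receptor 2 (Homo sapiens), read by BRET and beta-arrestin recruitment; a lower number here means a stronger inhibitor, a higher number a weaker inhibitor. Compound 1, `O=C(O)Cc1sc(C(c2ccc(F)cc2)c2ccc(F)cc2)nc1-c1cc(F)cc(F)c1`, gives 340 nM. Compound 2, `O=C(O)Cc1sc(C(c2ccc(F)cc2)c2ccc(F)cc2)nc1-c1ccoc1`, gives 130 nM. Compound 3, `NS(=O)(=O)c1cccc(-c2nc(C(c3ccc(F)cc3)c3ccc(F)cc3)sc2CC(=O)O)c1`, gives 710 nM, the highest number of the three: its nearest neighbour is compound 1, and the gap between them is a 2.1-fold higher number from compound 1 to compound 3 (0.32 log units; beyond the scatter), while the wider gap is a 5.5-fold higher number from compound 2 to compound 3 (0.74 log units; beyond the scatter).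

Compound 4, `Cc1cc(-c2nc(C(c3ccc(F)cc3)c3ccc(F)cc3)sc2CC(=O)O)cnc1N`, differs from compound 3 in one place: 6-amino-5-methylpyridin-3-yl in place of 3-sulfamoylphenyl on an aromatic carbon.

Within the data shown here, no measured step replaces one ring by this exact ring, so only indirect guidance exists. All three measured steps change the group at the same position, and each moved the number by a modest amount: a 2.6-fold lower number from compound 1 to compound 2 (0.42 log units; beyond the scatter), a 2.1-fold higher number from compound 1 to compound 3 (0.32 log units; beyond the scatter) and a 5.5-fold higher number from compound 2 to compound 3 (0.74 log units; beyond the scatter). The incoming group keeps the same count of donors and acceptors as the leaving one, so a modest step in either direction is plausible, with a slight lean towards a lower number since compound 3 already sits at the top.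

Compound 4 is therefore expected to give 450 nM in this assay, in a range from 150 nM to 1300 nM, an estimated step of a 1.6-fold lower number from compound 3 to compound 4 (0.20 log units; within the scatter).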

Compound 4, half-maximal inhibitory concentration: > 100000 nM
Compound 4: only a limit was reported (the forecaster's own chance of this, stated with the estimate: 3%); at least 220-fold (2.34 log units) between middle value and limit.
By their numbers in this assay, from the lowest: compound 2; then compound 1; then compound 3. At a limit, above all of these: compound 4.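

The earlier compounds shown here showed this position, on the aromatic carbon next to the ring nitrogen, carrying 3,5-difluorophenyl, furan-3-yl and 3-sulfamoylphenyl with only modest changes between them, but 6-amino-5-methylpyridin-3-yl does not fit that picture: in this assay there is an at least 140-fold higher number from compound 3 to compound 4 (2.14 log units; beyond the scatter). The change is also large measured against the other two groups, with an at least 760-fold higher number from compound 2 to compound 4 (2.88 log units; beyond the scatter) and an at least 290-fold higher number from compound 1 to compound 4 (2.46 log units; beyond the scatter), and since 3-sulfamoylphenyl and 6-amino-5-methylpyridin-3-yl have the same counts of hydrogen-bond donors and acceptors, those counts alone clearly do not decide the result at this position. The result for compound 4 is a limit of the assay and not a number: the limit of > 100000 nM in this assay, at which 1 of the 4 values shown sits.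

Still open, on these data alone, is which part of the new group goes with the loss: the amino group, the methyl group or the ring nitrogen. A pyridin-3-yl ring carrying only the amino group, only the methyl group or neither would help separate these three, and would show whether pyridine rings as such can sit at this position.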